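This account rests on a few compounds, and the source may have more. Where it says the series, first, only, none or still open, it means among the compounds named here.

Compound 1 `Cc1ccc(-n2cc(CNC(=O)c3cccc4c3cnn4C(C)C)nn2)c(C)c1`: in a functional assay on MGC-803 cells (Homo sapiens) for inhibition, read by MTT assay, with a stated time of 72 h (on this read-out lower numbers stand for stronger inhibition and higher numbers for weaker inhibition), compound 1 gives only a limit of the assay, > 40000 nM.
Compound 2 `CC(C)n1ncc2c(C(=O)NCc3cn(-c4ccc(C(F)(F)F)cc4)nn3)cccc21`: compound 2 likewise gives only a limit, > 40000 nM.
Compound 3 `CCc1ccc(-n2cc(CNC(=O)c3cccc4c3cnn4C(C)C)nn2)cc1`: compound 3 too gives only a limit, > 40000 nM.

All three values sit at the same limit (the limit of > 40000 nM in this assay, at which 3 of the 3 values shown sit), so compound 3 stands no different from the other two on the numbers shown. Compound 4 `COc1ccc(-n2cc(CNC(=O)c3cccc4c3cnn4C(C)C)nn2)cc1` differs from compound 3 by methoxy in place of ethyl on an aromatic carbon. The measured steps that bear on this change all alter the same phenyl group on the aromatic nitrogen: a step that the two limits leave unreadable from compound 1 to compound 3, a step that the two limits leave unreadable from compound 1 to compound 2 and a step that the two limits leave unreadable from compound 2 to compound 3. None of them can be read in size, so no direction is fixed for the step from compound 3 to compound 4. The expected step of a number no higher from compound 3 to compound 4 (the limit leaves the size open) is therefore taken as none beyond the scatter. Compound 4 is estimated at 40000 nM, with a range from 15000 nM to 100000 nM.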

Compound 4, half-maximal inhibitory concentration: > 40000 nM
Compound 4 gave a limit, no number; the forecaster's own chance of this, stated with the estimate: 80%; the middle value sits exactly at the limit.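

Compound 4 gives only a limit, as do compound 1, compound 2 and compound 3, so no step from compound 4 to any of them can be read: the limit of > 40000 nM in this assay, at which 4 of the 4 values shown sit.

The compounds shown leave open how strongly each one inhibits and whether the changes among them make any difference.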